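The source may report more compounds than this note shows. Statements on the series, on what has been measured and on what is new or still open speak of the compounds shown alone.

Compound 1 `C[C@]1(C(=O)O)CC[C@H](C(=O)N2CC[C@](c3ccc(C(F)(C(F)(F)F)C(F)(F)F)cc3)(S(=O)(=O)c3ccc(F)cc3)C2)CC1`: 97%
Compound 2 `O=C(O)C1CCC(O)(C(=O)N2CC[C@](c3ccc(C(F)(C(F)(F)F)C(F)(F)F)cc3)(S(=O)(=O)c3ccc(F)cc3)C2)CC1`: 100%; 95% (2 entries)
Compound 3 `O=C(O)C12CCC(C(=O)N3CC[C@](c4ccc(C(F)(C(F)(F)F)C(F)(F)F)cc4)(S(=O)(=O)c4ccc(F)cc4)C3)(CC1)C2`: "not determined" (no result reported)

In an ADME assay on microsomes from liver (Homo sapiens) for metabolic stability, with a stated time of 10 min (on this read-out higher numbers stand for a more stable compound and lower numbers for a less stable compound), compound 1 gives 97% and compound 2 gives 100%; 95% (2 entries), so both sit high on the scale. Compound 3 has no number in this assay, which leaves its standing open and gives no measured starting point for the next step.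

That step leads to compound 4 `O=C([C@H]1CC[C@H](c2nnn[nH]2)CC1)N1CC[C@](c2ccc(C(F)(C(F)(F)F)C(F)(F)F)cc2)(S(=O)(=O)c2ccc(F)cc2)C1`. The structural change runs (a group of 11 heavy atoms (7 carbon, 4 nitrogen; one five-membered aromatic ring with 4 hetero atoms, one six-membered non-aromatic ring of carbon only) in place of a group of 10 heavy atoms (8 carbon, 2 oxygen; 2 five-membered non-aromatic rings of carbon only), on a carbonyl carbon). It swaps one group on the carbonyl carbon for another and leaves the rest of the molecule as it was.

With compound 1 at 97% as the nearest guide, no shift beyond the usual scatter is expected in this assay, in either direction. Compound 4 is estimated at 92%, with an expected range of 75% to 100%.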

Compound 4, percent of the compound remaining: 100%
For compound 4 the middle estimate is 8 percentage points below the measured one, and the stated range covers the measured number.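

Putting 4-(1H-tetrazol-5-yl)cyclohexyl in place of 4-carboxy-4-methylcyclohexyl on the carbonyl carbon gives a number 3 percentage points higher from compound 1 to compound 4 (within the scatter) in this assay. For this pair, the high reading therefore does not depend on keeping the carboxylic acid, as a tetrazole serves equally well. A gap of this size is no larger than repeat readings of one compound can show: the several entries of compound 2 in this assay, 100%; 95% (2 entries)

Going by these compounds, it remains open whether a cyclohexyl group carrying an amine or a primary amide would also read high on this carbonyl carbon. On these data alone, every reading shown sits high, so which group here would lower the value is unknown.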